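A few compounds are considered here, and "the series" means these few. Any claim that something is new, unique, unknown or untested is made for them only; others in the source may bear on it.

Compound 1 `COc1ccc(Nc2nc3ccccc3nc2S(=O)(=O)c2ccccc2)cc1` gives 2420 nM in a functional assay on HCT-116 cells (Homo sapiens) for cytotoxicity, read by MTT assay, with a stated time of 72 h; on this read-out lower numbers stand for stronger inhibition and higher numbers for weaker inhibition.
Compound 2 `Nc1ccc(Nc2nc3ccccc3nc2S(=O)(=O)c2ccccc2)cc1` gives 10800 nM.
Compound 3 `O=S(=O)(c1ccccc1)c1nc2ccccc2nc1Nc1ccc(Cl)cc1` gives 2000 nM.

Compound 3 has the lowest of these three numbers, though the step of a 1.2-fold lower number from compound 1 to compound 3 (0.08 log units; within the scatter) is within the scatter, so those two cannot be ranked; the step of a 5.4-fold lower number from compound 2 to compound 3 (0.73 log units; beyond the scatter) is the only clear one it takes part in. Compound 4 `O=S(=O)(c1ccc(Br)cc1)c1nc2ccccc2nc1Nc1ccc(Cl)cc1` differs from compound 3 by bromo in place of hydrogen on an aromatic carbon. Every measured step, namely a 4.5-fold higher number from compound 1 to compound 2 (0.65 log units; beyond the scatter), a 1.2-fold lower number from compound 1 to compound 3 (0.08 log units; within the scatter) and a 5.4-fold lower number from compound 2 to compound 3 (0.73 log units; beyond the scatter), changes a group on a different ring of the shared core, and none touches the ring that now gains bromo. Among the measured compounds shown here, no measured step therefore bears directly on this change, and only a small step, if any beyond the scatter, is expected. Compound 4 is estimated at 1800 nM, with a range from 600 nM to 5500 nM. The expected step is a 1.1-fold lower number from compound 3 to compound 4 (0.05 log units; within the scatter), within the scatter.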

Compound 4, half-maximal inhibitory concentration: 10600 nM
Compound 4: middle estimate off by 5.9-fold (0.77 log units), on the low side, and the stated range ends below it.
By their numbers in this assay, from the lowest: compounds 3 and 1 (each within the scatter of the next); then compounds 4 and 2 (each within the scatter of the next).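

The phenyl ring that stayed the same in compounds 1, 2 and 3 proves sensitive to substitution in this assay: going from phenyl to 4-bromophenyl gives a 5.3-fold higher number from compound 3 to compound 4 (0.72 log units; beyond the scatter), a clear move towards weaker inhibition. A change on this ring can therefore matter, even though it adds only a single heavy atom. Nothing available here accounts for this loss.

From the compounds shown here alone, whether the loss is specific to bromo or would follow from any group at this place remains open. A fluoro group or a carboxylic acid on this ring could help to settle that.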